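Swapping Methoxy for Phenyl on a Biaryl Scaffold

This account rests on a few compounds, and the source may have more. Where it says the series, first, only, none or still open, it means among the compounds named here.

Measured so far:
compound 1 `CC(C)c1cc(C(C)(C)C)cc(-c2ccccc2-c2ccccc2)c1CO` – 3200 nM
compound 2 `COc1ccc(-c2cc(C(C)(C)C)cc(C(C)C)c2CO)cc1` – 1300 nM
compound 3 `COc1ccccc1-c1cc(C(C)(C)C)cc(C(C)C)c1CO` – 820 nM

All three compounds were tested in a functional assay on RKE cells for antagonist activity at Vasoactive intestinal polypeptide receptor 1 (Rattus norvegicus), read by HTRF and cAMP accumulation, with stated times of 10 min and 30 min; on this read-out lower numbers stand for stronger inhibition and higher numbers for weaker inhibition. In this assay compound 3 gives 820 nM, compound 2 gives 1300 nM and compound 1 gives 3200 nM. Compound 2 and compound 3 are built from the same atoms joined differently; the difference between the two cores is not broken down here, and their two values lie within the usual scatter of each other.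

Compound 1 differs from compound 3 in one place, (phenyl in place of methoxy on an aromatic carbon), and this brought a 3.9-fold higher number from compound 3 to compound 1 (0.59 log units; beyond the scatter).

The unmeasured compound 4 `CC(C)c1cc(C(C)(C)C)cc(-c2ccc(-c3ccccc3)cc2)c1CO` arises from compound 2 by the same kind of change, (phenyl in place of methoxy on an aromatic carbon). The two changes are of the same kind but not the same: in compound 1 the phenyl sits ortho to a large group, in compound 4 it sits para to a large group, so the earlier step is a guide rather than a rule.

Among the measured compounds shown here, with only one example of this swap, the expectation for compound 4 is a step of about the same size and direction as the one from compound 3 to compound 1, because a 3.9-fold higher number from compound 3 to compound 1 (0.59 log units; beyond the scatter) is the sole measured precedent; compound 4 is therefore expected to show a 3.5-fold higher number from compound 2 to compound 4 (0.54 log units; beyond the scatter) relative to compound 2. On this basis compound 4 is estimated at 4500 nM in this assay, most likely between 1500 nM and 13000 nM.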

Compound 4, half-maximal inhibitory concentration: 680 nM
Compound 4: the middle estimate sits 6.6-fold (0.82 log units) above what was measured; measured number below the stated range.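

In this assay the swap of methoxy for phenyl gave a 1.9-fold lower number from compound 2 to compound 4 (0.28 log units; within the scatter) and that step stays inside the usual scatter, so on this core the swap leaves no clear mark on the read-out. Set beside the earlier step, the result shows that this change does not carry from one core to the other as a fixed step, and a step measured on one core in this series is a poor guide to the same change on the other: the same change on two cores in this assay, a 3.9-fold higher number (0.59 log units; beyond the scatter) from compound 3 to compound 1 and a 1.9-fold lower number (0.28 log units; within the scatter) from compound 2 to compound 4, 7.5-fold (0.87 log units) apart, beyond the scatter of two such steps. Among the compounds shown here, it does not show why the two cores part, since each core offers only a single pair of compounds; the phenyl of compound 4 sits para to a large group, but these data cannot say whether that placing or some other feature of the core accounts for the gap.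

The compounds shown leave open how other groups would behave in the place of the methoxy, for example an amine, a carboxylic acid or a longer chain. They also leave open whether such groups would follow the large step seen with compound 1 or the step within the scatter seen with compound 4.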